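Swapping a Methylphenyl for Pyridinyl in Compound 2

A few compounds are considered here, and "the series" means these few. Any claim that something is new, unique, unknown or untested is made for them only; others in the source may bear on it.

Compound 2 `Cc1ccccc1CN(Cc1cc(=O)[nH]c2c(F)c(F)ccc12)c1cnccn1` gives 10 nM in an assay on HEK293 cells for inhibition of Nitric oxide synthase, inducible (Homo sapiens), read by fluorescence (a higher number here means a weaker inhibitor, a lower number a stronger inhibitor), the lowest of the two numbers in hand, while compound 1 `O=c1cc(CN(Cc2ccc(Cl)cc2)c2cnccn2)c2ccc(F)c(F)c2[nH]1` gives 77 nM. The gap between them, a 7.7-fold lower number from compound 1 to compound 2 (0.89 log units; beyond the scatter), arose from a single exchange on a saturated chain carbon bound to a nitrogen on an aromatic ring. Compound 3 `O=c1cc(CN(Cc2ccccn2)c2cnccn2)c2ccc(F)c(F)c2[nH]1` carries a further exchange at that same place: pyridin-2-yl in place of 2-methylphenyl on a saturated chain carbon bound to a nitrogen on an aromatic ring. Among the compounds with values here, no measured step covers this particular swap, so the direction is open. The expected step is a 3.0-fold higher number from compound 2 to compound 3 (0.48 log units; beyond the scatter). Compound 3 is estimated at 30 nM in this assay, within a range from 8 nM to 120 nM.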

Compound 3, half-maximal inhibitory concentration: 78 nM
The estimate for compound 3 lay 2.6-fold (0.41 log units) below the measured number; the measured number falls inside the stated range.
By their numbers in this assay, from the lowest: compound 2; then compounds 1 and 3 (each within the scatter of the next).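

The exchange of 2-methylphenyl for pyridin-2-yl gives a 7.8-fold higher number from compound 2 to compound 3 (0.89 log units; beyond the scatter) and so does not keep the low number of compound 2. Pyridin-2-yl in place of 4-chlorophenyl gives a 1.0-fold higher number from compound 1 to compound 3 (0.01 log units; within the scatter) and leaves these two groups level, so that among the three compounds only the 2-methylphenyl of compound 2 stands apart. Nothing available here explains these differences.

As far as these compounds go, what pyridin-3-yl or pyridin-4-yl would give at this place remains open. From the compounds shown here alone, it is also open whether 2-chlorophenyl would match 2-methylphenyl or 4-chlorophenyl.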